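A Shorter Hydroxycarbamoyl Chain and Its Expected Cost

This account rests on a few compounds, and the source may have more. Where it says the series, first, only, none or still open, it means among the compounds named here.

Measured so far:
compound 1 `CCOc1cc(C(C)(C)C)ccc1C1=NC(c2ccc(Cl)cc2)C(c2ccc(Cl)cc2)N1C(=O)N1CCN(CCCCCCCC(=O)NO)CC1` gives 1710 nM
compound 2 `CCOc1cc(C(C)(C)C)ccc1C1=NC(c2ccc(Cl)cc2)C(c2ccc(Cl)cc2)N1C(=O)NCCCCCCC(=O)Nc1ccccc1N` gives 10100 nM
compound 3 `CCOc1cc(C(C)(C)C)ccc1C1=NC(c2ccc(Cl)cc2)C(c2ccc(Cl)cc2)N1C(=O)NCCCCCC(=O)Nc1ccccc1N` gives 21800 nM
compound 4 `CCOc1cc(C(C)(C)C)ccc1C1=NC(c2ccc(Cl)cc2)C(c2ccc(Cl)cc2)N1C(=O)N1CCN(CCCCCC(=O)NO)CC1` is not yet measured

All three measured compounds share one core and were tested in a functional assay on HCT-116 cells (Homo sapiens) for antiproliferative activity, read by CCK-8 assay, with a stated time of 72 h; on this read-out lower numbers stand for stronger inhibition and higher numbers for weaker inhibition. Compound 1 has the lowest number of the three, so it is the strongest inhibitor; compound 2 and compound 3 both sit well above it, beyond the scatter.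

Compound 4 keeps everything in compound 1 except the tail: hydroxycarbamoyl in place of 2-(hydroxycarbamoyl)ethyl on a saturated chain carbon, five bonds along the chain from an amine nitrogen in a ring. The tail is thus cut shorter while its end group stays.

One measured step speaks to a change of this kind. The step of a 2.2-fold higher number from compound 2 to compound 3 (0.33 log units; beyond the scatter) shortens a tail of the same sort by a smaller amount and weakens the inhibition modestly. For the measured compounds named here, compound 4 shortens its tail further than that, so a somewhat larger loss is expected, though with only one comparison the size is uncertain.

Compound 4 is therefore expected to show a step of a 2.6-fold higher number from compound 1 to compound 4 (0.42 log units; beyond the scatter) in this assay, toward weaker inhibition, and its value is estimated at 4500 nM, within a range from 1700 nM to 12000 nM.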

Compound 4, half-maximal inhibitory concentration: 4030 nM
Beside the measured number, compound 4's estimate is 1.1-fold (0.05 log units) above it; the range from low to high includes it.
By their numbers in this assay, from the lowest: compound 1; then compound 4; then compound 2; then compound 3.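

In this assay, for the compounds shown here, the change from 5-(hydroxycarbamoyl)pentyl to 3-(hydroxycarbamoyl)propyl gives a 2.4-fold higher number from compound 1 to compound 4 (0.37 log units; beyond the scatter) and so shows something the earlier compounds could not: what shortening does when the hydroxycarbamoyl end group stays and the tail sits on an amine nitrogen in a ring. Going by these compounds alone, until now, shortening had been seen only with the (2-aminophenyl)carbamoyl end group, in the step of a 2.2-fold higher number from compound 2 to compound 3 (0.33 log units; beyond the scatter) and the new step points the same way, so in both pairs the shorter tail goes with the higher number and neither pair goes against that. Both steps are modest, so shortening weakens the inhibition without abolishing it, but nothing measured here explains why the number rises.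

The compounds shown leave open whether a longer chain than the one in compound 1 would lower the number further or raise it again, and whether a still shorter chain would continue the rise. They also leave open what a carboxylic acid or a primary amine at the end of the same chain would do, which would tell how much the activity in this assay depends on the hydroxycarbamoyl group itself.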